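Chlorobenzylsulfanyl positional swap in an oral vasorelaxant series

This account rests on a few compounds, and the source may have more. Where it says the series, first, only, none or still open, it means among the compounds named here.

Measured compounds:
compound 1, `CC1=C(C(=O)Nc2ccc(F)cc2)C(c2ccc([N+](=O)[O-])cc2)N=C(SCc2cccc(Cl)c2)N1`: 18.5%
compound 2, `CC1=C(C(=O)Nc2ccc(F)cc2)C(c2ccc([N+](=O)[O-])cc2)N=C(SCc2ccc(Cl)cc2)N1`: 37.9%
compound 3, `COc1ccc(C2N=C(SCc3cccc(Cl)c3)NC(C)=C2C(=O)Nc2ccc(Br)cc2)cc1`: 39%

All three were run in a functional assay on the whole organism (artery, strain albino) with Rattus norvegicus as the target, with a stated time of 300 min, at a dose of 10 mg/kg by the oral route; on this read-out higher numbers stand for more inhibition at the one dose given (going by the name of the read-out) and lower numbers for less inhibition. Compound 1 gives 18.5%, compound 2 gives 37.9% and compound 3 gives 39%. Compounds 1 and 2 share a core and differ only in the chlorine position: 4-chlorophenyl in place of 3-chlorophenyl on a saturated chain carbon bound to a sulfur. This change gave a number 19.4 percentage points higher from compound 1 to compound 2 (beyond the scatter). Compound 3 rests on a different core; the difference between the two cores is not broken down here. Compound 2 and compound 3 lie within the scatter of each other in this assay , so no order between them is claimed.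

Compound 4, `COc1ccc(C2N=C(SCc3ccc(Cl)cc3)NC(C)=C2C(=O)Nc2ccc(Br)cc2)cc1`, is not yet measured. It stands to compound 3 as compound 2 stands to compound 1: 4-chlorophenyl in place of 3-chlorophenyl on a saturated chain carbon bound to a sulfur. The place is the same in both pairs, so this is the same change made on a second core. Among the compounds with values here, the one measured instance of it is the step from compound 1 to compound 2 in this assay , which lay beyond the scatter. With a single precedent on a different core, a rise of similar direction but uncertain size is expected for compound 4, giving a number 13 percentage points higher from compound 3 to compound 4 (beyond the scatter). Within the data shown here, compound 4 is therefore estimated at 52% in this assay , with a range from 32% to 72%, the width reflecting that only one earlier step supports the expectation.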

Compound 4, a percentage reported as inhibition, in the whole organism at one dose (the size of the read-out at that dose, not a potency): 37.9%
Beside the measured number, compound 4's estimate is 14.1 percentage points above it, and the stated range covers the measured number.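

In this assay, the change from 3-chlorobenzyl to 4-chlorobenzyl does not carry over with the same outcome from one core to the other: the same change on two cores in this assay, a number 19.4 percentage points higher (beyond the scatter) from compound 1 to compound 2 and a number 1.1 percentage points lower (within the scatter) from compound 3 to compound 4, 20.5 percentage points apart, beyond the scatter of two such steps. On the second core the result reads a number 1.1 percentage points lower from compound 3 to compound 4 (within the scatter), so no gain can be read there, and the rise seen with the core of compound 1 stands for that one pair only. The difference between the two steps shows that the outcome of this change depends on the core in this small set, but it does not show which part of the cores matters, and with one pair per core it gives no measure of how general either step is.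

As far as these compounds go, all four compounds carry a chlorobenzyl on the sulfur, so it stays open how this assay responds to an unsubstituted benzyl, a longer alkyl chain or a chain ending in an amine at that place. Also open, from the compounds shown here alone, is whether the two steps would keep their relation at other doses, or on further cores that differ from these two in only one place.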